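This account rests on a few compounds, and the source may have more. Where it says the series, first, only, none or still open, it means among the compounds named here.

Compound 1, `O=C(Nc1cccc(-n2cc(-c3ccncc3)c(-c3cc(O)cc(Cl)c3)n2)c1)Nc1ccc(Cl)c(C(F)(F)F)c1`, is the reference point of the set. In a functional assay on RXF 393 cells (Homo sapiens) for inhibition, read by sulforhodamine B assay, with a stated time of 48 h, tested at 10 uM (on this read-out lower numbers stand for a stronger effect and higher numbers for a weaker effect at the one concentration tested), compound 1 gives -49.5%. Compound 2, `COc1cc(Cl)cc(-c2nn(-c3cccc(NC(=O)Nc4ccc(Cl)c(C(F)(F)F)c4)c3)cc2-c2ccncc2)c1`, differs from it by one change, (methyl in place of hydrogen on an oxygen on an aromatic ring), and in this assay compound 2 gives -30%; the result is a number 19.5 percentage points higher from compound 1 to compound 2 (beyond the scatter). Compound 3, `O=C(Nc1cccc(-n2cc(-c3ccncc3)c(-c3cc(O)cc(Cl)c3)n2)c1)c1cc(C(F)(F)F)cc(C(F)(F)F)c1`, carries a different core, and the difference between the two cores is not broken down here. In this assay compound 3 gives -10.4%, the highest of the three values, lying beyond the scatter from both compound 2 and compound 1. Compound 4, `COc1cc(Cl)cc(-c2nn(-c3cccc(NC(=O)c4cc(C(F)(F)F)cc(C(F)(F)F)c4)c3)cc2-c2ccncc2)c1`, has not been measured; it differs from compound 3 by methyl in place of hydrogen on an oxygen on an aromatic ring, the same change that separates compound 1 from compound 2, so the change appears in two pairs of compounds, and the places are described in the same words. For compound 4 a step of a number 18.4 percentage points higher from compound 3 to compound 4 (beyond the scatter) is expected in this assay, an expectation that rests on the step of a number 19.5 percentage points higher from compound 1 to compound 2 (beyond the scatter) seen with the same change. Compound 4 is therefore estimated at 8%, within a range from -10% to 26%.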

Compound 4, a percentage reported as activity, at one concentration (the size of the read-out at that concentration, not a potency): 67.7%
Compound 4: the middle estimate sits 59.7 percentage points below what was measured, outside the stated range (above it).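

The change from hydroxy to methoxy gives a number 78.1 percentage points higher from compound 3 to compound 4 (beyond the scatter) in this assay, and set beside the earlier step, its size does not carry from one core to the other: the same change on two cores in this assay, a number 19.5 percentage points higher (beyond the scatter) from compound 1 to compound 2 and a number 78.1 percentage points higher (beyond the scatter) from compound 3 to compound 4, 58.6 percentage points apart, beyond the scatter of two such steps The direction is the same in both pairs, so the number rises with methoxy on each core, but two pairs are too few to make this a rule for the series. Nor do they show which part of the difference between the two cores goes with the larger step, and as these are readings at one concentration, they say nothing about potency.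

From the compounds shown here alone, it remains open whether the larger step belongs to the core of compound 3 alone or would recur on other cores. Also open, going by these compounds, is how an ethoxy group or an amine in place of the hydroxy would read on either core.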